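Exchanging dimethylamino for methoxy beside a benzofuran substituent

The compounds below may be only part of what the source reports. "The series", "measured", "known", "first", "only" and "open" are said of these compounds alone.

Measured compounds:
compound 1, `COc1ncnc2c1c(-c1cccs1)cn2[C@@H]1O[C@H](CO)[C@@H](O)[C@H]1O`, 70 nM
compound 2, `CN(C)c1ncnc2c1c(-c1cc3ccccc3o1)cn2[C@@H]1O[C@H](CO)[C@@H](O)[C@H]1O`, only a limit in this assay
compound 3, `C#Cc1cn([C@@H]2O[C@H](CO)[C@@H](O)[C@H]2O)c2ncnc(N(C)C)c12`, 110 nM

In a functional assay on K562 cells (Homo sapiens), read by MTT assay, with a stated time of 72 h (a lower number here means a stronger inhibitor, a higher number a weaker inhibitor), compound 2 reaches only the assay limit, recorded as > 20000 nM. This places compound 2 at the limit of > 20000 nM in this assay, at which 1 of the 3 values shown sits, at the weak end of the three numbers shown, whereas compound 1 and compound 3 both give well-defined values. Going by the values given here, the step of an at least 180-fold lower number from compound 2 to compound 3 (2.25 log units; beyond the scatter) removes the benzofuran group and is the only measured step touching compound 2.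

Compound 4, `COc1ncnc2c1c(-c1cc3ccccc3o1)cn2[C@@H]1O[C@H](CO)[C@@H](O)[C@H]1O`, keeps the benzofuran group and differs from compound 2 only by methoxy in place of dimethylamino on an aromatic carbon. Among the compounds with values here, no measured step changes the dimethylamino group on its own; compound 1 carries methoxy and compound 3 carries dimethylamino, and both are active, but they also differ in their aromatic substituent, so they show only that either group can sit on an active compound. The benzofuran group shared with compound 2 is therefore expected to dominate, and compound 4 is estimated to stay near the limit, with the step of an at least 1.3-fold lower number from compound 2 to compound 4 (0.12 log units; that floor lies within the scatter) expected to be small or within the scatter. The expected value for compound 4 in this assay is 15000 nM, within 2500 nM to 60000 nM.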

Compound 4, half-maximal inhibitory concentration: 20900 nM
Beside the measured number, compound 4's estimate is 1.4-fold (0.14 log units) below it; the range from low to high includes it.
By their numbers in this assay, from the lowest: compounds 1 and 3 (each within the scatter of the next); then compound 4.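

With methoxy held constant, compound 1 and compound 4 isolate the exchange of thiophen-2-yl for 1-benzofuran-2-yl in this assay, giving a 300-fold higher number from compound 1 to compound 4 (2.48 log units; beyond the scatter). Going by these compounds alone, the earlier loss tied to the benzofuran group was seen only with dimethylamino and against a limit, whereas this measured step shows that the weak result also occurs with methoxy. The exchange of dimethylamino for methoxy itself cannot be read, because compound 2 stands at a limit: the limit of > 20000 nM in this assay, at which 1 of the 4 values shown sits.

As far as these compounds go, whether methoxy and dimethylamino differ on compounds carrying thiophen-2-yl or ethynyl remains open. Also open, from the compounds shown here alone, is how an unsubstituted amine or a longer alkoxy chain would fare in this place on the six-membered aromatic ring.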